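Methoxyphenyl to hydroxyphenyl: what the next compound might show

The source may hold more compounds than are shown below. What is called first, only, known or untested is meant among the compounds shown, and "the series" means these compounds.

Compound 1, `CC(C)(C)c1cn(C[C@H](O)[C@H]2OC(=O)C(OCc3ccccc3)=C2OCc2ccccc2)nn1`: in a functional assay on A549 cells (Homo sapiens) for antiproliferative activity, read by MTT assay, with a stated time of 72 h (a higher number here means a weaker inhibitor, a lower number a stronger inhibitor), compound 1 gives 34000 nM.
Compound 2, `COc1ccc(-c2cn(C/C=C3\OC(=O)C(OCc4ccccc4)=C3OCc3ccccc3)nn2)cc1`: in this assay compound 2 gives > 100000 nM.

Compound 1 is the only one of the two with a number of its own in this assay. Compound 2 stands at a limit of the assay, not at a number, so where it truly sits is known only as a range beyond that limit (the limit of > 100000 nM in this assay, at which 1 of the 2 values shown sits). For the measured compounds named here, no pair of measured compounds here differs in a single place, so no measured step is available to guide what a small change does.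

Compound 3, `O=C1O/C(=C\Cn2cc(-c3cccc(O)c3)nn2)C(OCc2ccccc2)=C1OCc1ccccc1`, differs from compound 2 in one place: 3-hydroxyphenyl in place of 4-methoxyphenyl on an aromatic carbon. Going by the values given here, with only a limit for compound 2 and no measured step of comparable kind, the expectation for this change is no shift beyond the usual scatter in this assay, which is what the step of a number no higher from compound 2 to compound 3 (the limit leaves the size open) is meant to express. Compound 3 is therefore estimated at 100000 nM, within a range from 30000 nM to 300000 nM, with a real chance that the assay again reports only a limit.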

Compound 3, half-maximal inhibitory concentration: 23300 nM
Estimate against measurement, compound 3: 4.3-fold (0.63 log units) above, and the stated range ends above it.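

In this assay, for the compounds shown here, replacing 4-methoxyphenyl with 3-hydroxyphenyl gives an at least 4.2-fold lower number from compound 2 to compound 3 (0.63 log units; beyond the scatter), the first measured step in this set. It shows that the group on the five-membered aromatic ring is not a silent place: a change there alone, with the rest of the molecule left as it is, is enough to bring a compound from a limit of the assay to a number of its own. The full size of the step cannot be read because compound 2 stands at a limit and not at a number: the limit of > 100000 nM in this assay, at which 1 of the 3 values shown sits.

The change also alters two things at once, since the oxygen now carries a hydrogen rather than a methyl group and the group is 3-substituted rather than 4-substituted, so this single step cannot say which of the two matters; 4-hydroxyphenyl and 3-methoxyphenyl would pull them apart. As far as these compounds go, whether the oxygen itself is needed at all also remains open, and 3-aminophenyl, with an amine in its place, or plain phenyl, with no such group, would begin to answer that.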